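Adding a Second Ring: Expected Cytotoxicity of Compound 4

The source may hold more compounds than are shown below. What is called first, only, known or untested is meant among the compounds shown, and "the series" means these compounds.

Of the compounds shown here, three have been measured in an ADME assay on L6 cells (Rattus norvegicus) for cytotoxicity; on this read-out lower numbers stand for stronger inhibition and higher numbers for weaker inhibition. Compound 1 `c1ccc(Nc2ccc(NC3=NCCN3)cc2)cc1` gives 90700 nM. Compound 2 `c1ccc(Sc2ccc(NC3=NCCN3)cc2)cc1` gives the lowest number of the three, 28500 nM, which marks it as the strongest inhibitor among them. Compound 3 `c1cc(Nc2ccc(NC3=NCCN3)cc2)ccc1NC1=NCCN1` gives 212000 nM. Compound 3 arises from compound 1 by a single change (a group of 6 heavy atoms (3 carbon, 3 nitrogen; one five-membered non-aromatic ring with 2 hetero atoms) in place of a hydrogen atom, on an aromatic carbon). The size of that step is a 2.3-fold higher number from compound 1 to compound 3 (0.37 log units; beyond the scatter), so the change weakened inhibition by a modest but real amount.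

Compound 4 `c1cc(Sc2ccc(NC3=NCCN3)cc2)ccc1NC1=NCCN1` is not yet measured. It arises from compound 2 by the change (a group of 6 heavy atoms (3 carbon, 3 nitrogen; one five-membered non-aromatic ring with 2 hetero atoms) in place of a hydrogen atom, on an aromatic carbon). Among the compounds with values here, the place of the entering group is described in exactly the same words, so this is the same change as the one from compound 1 to compound 3. The cores of compound 1 and compound 2 differ, but the difference between the two cores is not broken down here; in this assay compound 1 and compound 2 stand apart, with compound 2 the lower.

Because a 2.3-fold higher number from compound 1 to compound 3 (0.37 log units; beyond the scatter) shows this change raising the number modestly, the expectation is a step of similar size, a 2.3-fold higher number from compound 2 to compound 4 (0.36 log units; beyond the scatter). That rests on one observed pair only, so the expectation is loose. The estimate for compound 4 in this assay is 65000 nM, expected to fall between 30000 nM and 150000 nM.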

Compound 4, half-maximal inhibitory concentration: 23300 nM
The estimate for compound 4 lay 2.8-fold (0.45 log units) above the measured number; the whole stated range lies above it.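

In this assay, the same change on the second core gives a 1.2-fold lower number from compound 2 to compound 4 (0.09 log units; within the scatter), so here the entering group produces no difference that can be told apart from the ordinary spread of repeated measurements. Set beside the earlier step, this result shows that the effect of the change did not carry over unchanged from one core to the other in this assay: the same change on two cores in this assay, a 2.3-fold higher number (0.37 log units; beyond the scatter) from compound 1 to compound 3 and a 1.2-fold lower number (0.09 log units; within the scatter) from compound 2 to compound 4, 2.9-fold (0.46 log units) apart, beyond the scatter of two such steps. Within the data shown here, it does not show why the two cores respond differently, and with only one pair on each core it cannot say which result is more typical of the series, or whether either would hold on a further core.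

The compounds shown leave open how either core would respond if the same aromatic carbon carried a different group, such as a simple amine, a carboxylic acid or a longer chain, in place of the hydrogen atom. They also leave open whether a third core would behave like the pair of compound 1 and compound 3 or like the pair of compound 2 and compound 4.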